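Amide change at the carbonyl of a chemokine receptor antagonist

This account rests on a few compounds, and the source may have more. Where it says the series, first, only, none or still open, it means among the compounds named here.

Compound 1 `CNC(=O)c1cnc(N2CCN(C3CCN(Cc4ccc(Cl)cc4)CC3)[C@@H](C)C2)c(Cl)c1` gives 32 nM in a functional assay for antagonist activity at C-X-C chemokine receptor type 3 (Homo sapiens) (a higher number here means a weaker inhibitor, a lower number a stronger inhibitor), the lowest of the two values known, while compound 2 `CNC(=O)c1cnc(N2CCN(C3CCN(Cc4ccc[nH]4)CC3)[C@@H](C)C2)c(Cl)c1` gives 8060 nM. Among the measured compounds shown here, the one measured step, a 250-fold higher number from compound 1 to compound 2 (2.40 log units; beyond the scatter), concerns a different part of the shared core and so does not bear on the change to compound 3 `C[C@H]1CN(c2ncc(C(=O)N3CCCCC3)cc2Cl)CCN1C1CCN(Cc2ccc(Cl)cc2)CC1`, which is piperidin-1-yl in place of methylamino on a carbonyl carbon. With nothing measured at the carbonyl, the size of the step is open; a modest loss is expected, a 3.1-fold higher number from compound 1 to compound 3 (0.49 log units; beyond the scatter), and compound 3 is estimated at 100 nM, within 15 nM to 800 nM.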

Compound 3, half-maximal inhibitory concentration: 900 nM
Beside the measured number, compound 3's estimate is 9.0-fold (0.95 log units) below it, outside the stated range (above it).
By their numbers in this assay, from the lowest: compound 1; then compound 3; then compound 2.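

At the carbonyl carbon, this assay shows a large change, a 28-fold higher number from compound 1 to compound 3 (1.45 log units; beyond the scatter) for piperidin-1-yl in place of methylamino, so this position is not indifferent to the group it carries. The change removes the hydrogen-bond donor of methylamino and brings in a six-membered non-aromatic ring, and this single step cannot separate those two differences. Nothing at hand accounts for the size of the step.

As far as these compounds go, it remains open whether the ring or the lost amide hydrogen matters more. Dimethylamino or ethylamino on the same carbonyl carbon could help separate them.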